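The source may report more compounds than this note shows. Statements on the series, on what has been measured and on what is new or still open speak of the compounds shown alone.

In a functional assay on HepG2 cells (Homo sapiens) for cytotoxicity, read by sulforhodamine B assay, with a stated time of 48 h (on this read-out lower numbers stand for stronger inhibition and higher numbers for weaker inhibition), compound 1 `COc1ccc(/C=C/C(=O)c2ccc(N)c(-c3ccc(F)cc3)c2)cc1O` has no number to start from, and its entry reads "not determined" (no result reported). Two related compounds do have results: compound 2 `O=C(/C=C/c1cccc(Br)c1)c1cccc(-c2cccc(F)c2)c1` gives 6980 nM, and compound 3 `COc1ccc(/C=C/C(=O)c2cccc(-c3cccc(F)c3)c2)cc1OC` gives 1170 nM. Compound 4 `COc1ccc(/C=C/C(=O)c2ccc(N)c(-c3ccc(F)cc3)c2)cc1OC` differs from compound 1 by a single change, (methyl in place of hydrogen on an oxygen on an aromatic ring), which is methyl in place of hydrogen on an oxygen on an aromatic ring, or hydroxy to methoxy. Going by the values given here, no measured pair shows this change, so its size can only be expected, and no step beyond the usual scatter is anticipated in either direction. The closest guide is compound 3 at 1170 nM, which also carries methoxy groups. The estimated value for compound 4 is 1800 nM, with an expected range of 500 nM to 7000 nM.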

Compound 4, half-maximal inhibitory concentration: 3780 nM
Compound 4: middle estimate off by 2.1-fold (0.32 log units), on the low side, and the stated range covers the measured number.
By their numbers in this assay, from the lowest: compound 3; then compounds 4 and 2 (each within the scatter of the next).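

Compound 4 gives [ 3780 nM ], but compound 1 has no number to compare it with, so no step can be read. On these data alone, the effect of changing hydroxy to methoxy stays open, and no supporting evidence is available.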